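Swapping the Carboxyphenyl of a Urea for Methylphenyl

The source may report more compounds than this note shows. Statements on the series, on what has been measured and on what is new or still open speak of the compounds shown alone.

Compound 1, with the structure `O=C(Nc1cccc(C(=O)O)c1)N[C@H]1CC[C@H](Oc2ccc(F)cc2)CC1`, is the starting point. In a functional assay on CRL2813 cells (Homo sapiens) for cytotoxicity, read by sulforhodamine B assay, with a stated time of 5 days (on this read-out lower numbers stand for stronger inhibition and higher numbers for weaker inhibition), compound 1 gives > 20000 nM, which is a limit of the assay and not a measured number. Compound 2, with the structure `O=C(Nc1cccc([N+](=O)[O-])c1)N[C@H]1CC[C@H](Oc2ccc(F)cc2)CC1`, differs from compound 1 only by nitro in place of carboxy on an aromatic carbon; in this assay compound 2 gives 6700 nM. From the compounds shown here alone, that change gives the step of an at least 2.9-fold lower number from compound 1 to compound 2 (0.47 log units; beyond the scatter), whose exact size stays open because of the limit of > 20000 nM in this assay, at which 1 of the 3 values shown sits. Compound 3, with the structure `O=C(Nc1cccc(C(F)(F)F)c1)N[C@H]1CC[C@H](Oc2ccc(Cl)cc2)CC1`, gives 2000 nM in this assay; it differs from the others in more than one place, so its value shows only the range a trifluoromethyl-bearing analogue reaches.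

Compound 4, with the structure `Cc1ccc(NC(=O)N[C@H]2CC[C@H](Oc3ccc(F)cc3)CC2)cc1`, is not yet measured. Its change from compound 1 is 4-methylphenyl in place of 3-carboxyphenyl on an amide-type nitrogen. Among the compounds with values here, the only measured step that bears on it is the one already described, where removing carboxy moved the number beyond the scatter toward stronger inhibition. Replacing 3-carboxyphenyl with 4-methylphenyl also removes carboxy. For compound 4 a step in the same direction is therefore expected: an at least 4.0-fold lower number from compound 1 to compound 4 (0.60 log units; beyond the scatter). Compound 4 is expected to give about 5000 nM in this assay, within a range from 1500 nM to 20000 nM.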

Compound 4, half-maximal inhibitory concentration: > 20000 nM
Compound 4: no number, only a limit; the forecaster's own chance of this, stated with the estimate: 20%; middle value at least 4.0-fold (0.60 log units) from the limit.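

Taking away the carboxy group is not enough on its own to lift this urea off the assay ceiling: compound 4 has no carboxy group, yet in this assay it too yields only a limit and not a measured number. The step between compound 1 and compound 4 cannot be read, since both stand at the same limit: the limit of > 20000 nM in this assay, at which 2 of the 4 values shown sit.

What can be read is that the group on this amide-type nitrogen still matters, as 4-methylphenyl in place of 3-nitrophenyl gives an at least 2.9-fold higher number from compound 2 to compound 4 (0.47 log units; beyond the scatter), so the lower number of the nitro compound does not follow from the loss of carboxy alone.

Because 3-nitrophenyl and 4-methylphenyl differ both in the group they carry and in the number in their names, these compounds cannot separate the effect of the group from the effect of where it sits: the limit of > 20000 nM in this assay, at which 2 of the 4 values shown sit. The compounds shown also give no reading for a phenyl bearing an amine or a nitrile, and none that sets trifluoromethyl directly against nitro on the same core.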